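Compound 3 and a proposed 3,5-dimethylphenyl change

The source may report more compounds than this note shows. Statements on the series, on what has been measured and on what is new or still open speak of the compounds shown alone.

Compound 1 `Cc1nc(-c2ccccc2)c(C(=O)N2CCN(c3cccc(Cl)c3Cl)CC2)o1`: 133 nM
Compound 2 `Cc1ccc(N2CCN(C(=O)c3oc(C)nc3-c3ccccc3)CC2)c(C)c1`: 101 nM
Compound 3 `COc1cccc(N2CCN(C(=O)c3oc(C)nc3-c3ccccc3)CC2)c1`: 34.8 nM

All three values come from a functional assay on HL-60 cells (Homo sapiens) for inhibition, read by MTT assay, with a stated time of 72 h; a higher number here means a weaker inhibitor, a lower number a stronger inhibitor. Compound 3 has the lowest number of the three, and its steps to both others lie beyond the scatter. Compound 4 `Cc1cc(C)cc(N2CCN(C(=O)c3oc(C)nc3-c3ccccc3)CC2)c1` carries 3,5-dimethylphenyl in place of 3-methoxyphenyl on an amine nitrogen in a ring.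

Among the compounds with values here, three measured steps bear on this change. The closest is a 2.9-fold lower number from compound 2 to compound 3 (0.46 log units; beyond the scatter), a modest step in which 3-methoxyphenyl takes the place of 2,4-dimethylphenyl. A similar modest step is a 3.8-fold lower number from compound 1 to compound 3 (0.58 log units; beyond the scatter). By contrast, a 1.3-fold lower number from compound 1 to compound 2 (0.12 log units; within the scatter) stays within the scatter. Within the data shown here, no measured compound carries 3,5-dimethylphenyl itself, so the evidence is indirect. Compound 2, with its two methyl groups, gives 101 nM, which points to a modest rise in this assay. The expected change is a 2.0-fold higher number from compound 3 to compound 4 (0.30 log units; within the scatter). Compound 4 is estimated at 70 nM, with an expected range from 30 nM to 160 nM.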

Compound 4, half-maximal inhibitory concentration: 34.5 nM
Beside the measured number, compound 4's estimate is 2.0-fold (0.31 log units) above it, and the stated range covers the measured number.
By their numbers in this assay, from the lowest: compounds 4 and 3 (each within the scatter of the next); then compounds 2 and 1 (each within the scatter of the next).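

In this assay, 3,5-dimethylphenyl in place of 3-methoxyphenyl gives a 1.0-fold lower number from compound 3 to compound 4 (0.00 log units; within the scatter) and so shows that, among these compounds, the oxygen of the methoxy group is not required on this amine nitrogen: a group of carbon only, with no hydrogen-bond acceptor, serves as well. Two methyl groups do not by themselves set the number, as the arrangement of those groups alone gives a 2.9-fold lower number from compound 2 to compound 4 (0.47 log units; beyond the scatter) and the 3,5-dimethylphenyl group also separates from 2,3-dichlorophenyl with a 3.9-fold lower number from compound 1 to compound 4 (0.59 log units; beyond the scatter) in the same assay. No measurement shown gives a reason for these steps.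

Left open is whether 3-methylphenyl, with one methyl group, or 3,5-dimethoxyphenyl would stay level with compound 3 and compound 4. Also open, going by these compounds, is how a phenyl ring bearing an amine or a carboxylic acid would read at this place.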